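The source may report more compounds than this note shows. Statements on the series, on what has been measured and on what is new or still open speak of the compounds shown alone.

Measured so far:
compound 1, `CCCCCOc1nc(N)c2nc(O)n(Cc3ccccc3)c2n1`, in a functional assay on the whole organism for activation, with Mus musculus as the target; on this read-out lower numbers stand for an effect already at smaller amounts and higher numbers for an effect only at larger amounts of compound: 0.3 mg/kg
compound 2, `CCCNc1nc(N)c2nc(O)n(Cc3ccccc3)c2n1`: 1 mg/kg
compound 3, `CCSc1nc(N)c2nc(O)n(Cc3ccccc3)c2n1`: 0.1 mg/kg

Compound 3 has the lowest number of the three, that is, it acts at the smallest dose: a 3.0-fold lower number from compound 1 to compound 3 (0.48 log units; beyond the scatter) and a 10-fold lower number from compound 2 to compound 3 (1.00 log units; beyond the scatter). The step to compound 4, `CCCCc1nc(N)c2nc(O)n(Cc3ccccc3)c2n1`, changes the same position once more: butyl in place of ethylsulfanyl on an aromatic carbon. Among the measured compounds shown here, no measured step exchanges the ethylsulfanyl for a plain carbon chain, so the bearing steps are only the two above, which show that swapping the group at this position moves the dose modestly in either direction. A modest rise beyond the scatter is therefore expected, a 3.0-fold higher number from compound 3 to compound 4 (0.48 log units; beyond the scatter). For compound 4 the estimate in this assay is 0.3 mg/kg, with a range from 0.1 mg/kg to 1 mg/kg.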

Compound 4, minimum effective dose: 0.3 mg/kg
Estimate against measurement, compound 4: no gap at the digits printed, within the range that was stated.
By their numbers in this assay, from the lowest: compound 3; then compounds 1 and 4 (each within the scatter of the next); then compound 2.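

Compound 4 shows that a chain of carbon alone can sit on this aromatic carbon and the compound still acts in this assay while differing in both directions from its neighbours: butyl gives up some ground to ethylsulfanyl (a 3.0-fold higher number from compound 3 to compound 4 (0.48 log units; beyond the scatter)) but gains on propylamino (a 3.3-fold lower number from compound 2 to compound 4 (0.52 log units; beyond the scatter)). Against pentyloxy the result is level (no change at the digits printed from compound 1 to compound 4 (within the scatter)), so these two chains cannot be told apart here. No evidence at hand explains these differences.

The compounds shown leave open how a longer chain such as hexyl, or a shorter sulfur group such as methylsulfanyl, would behave at this position. A phenyl ring here also remains an open case.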